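The source may hold more compounds than are shown below. What is called first, only, known or untested is meant among the compounds shown, and "the series" means these compounds.

Compound 3 `CCOCCNc1nc(N)nc2ccn(Cc3ccccn3)c12` is one of three compounds tested in an ADME assay on HEK293 cells (Homo sapiens) for cytotoxicity, read by ATP content, with a stated time of 6 h; a higher number here means that more compound is tolerated, a lower number that less compound is tolerated. In this assay compound 3 gives > 24000 nM, which is a limit of the assay and not a number. Compound 1 `CCCCNc1nc(N)nc2ccn(CC(=O)NC)c12` also reaches only a limit in this assay, giving > 24000 nM. Compound 2 `CCCCNc1nc(N)nc2ccn(Cc3nccs3)c12` likewise gives > 24000 nM, again a limit. What the numbers shown come down to is the limit of > 24000 nM in this assay, at which 3 of the 3 values shown sit, so compound 3 stands level with the other two as far as these values can tell. Within the data shown here, the only step between measured compounds that differ in one place is a step that the two limits leave unreadable from compound 1 to compound 2, and its size cannot be read. Compound 4 `Cc1nc(COc2nc(N)nc3ccn(Cc4ccccn4)c23)no1` differs from compound 3 by (5-methyl-1,2,4-oxadiazol-3-yl)methoxy in place of (2-ethoxyethyl)amino on an aromatic carbon. Among the measured compounds shown here, no measured step touches the same place or the same groups, and the one step that exists is unreadable, so there is no basis for expecting a shift beyond the scatter in this assay. The estimate for compound 4 is therefore 30000 nM, with a range from 12000 nM to 80000 nM, and most likely the assay will again report only a limit. The step this estimate means is a step that the limit leaves unreadable from compound 3 to compound 4, which is expected to stay within the scatter.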

Compound 4, half-maximal cytotoxic concentration: > 24000 nM
Compound 4: only a limit was reported (the forecaster's own chance of this, stated with the estimate: 80%); the middle value does not contradict the limit.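

In this assay compound 4 gives > 24000 nM, which is a limit of the assay and not a number. Among these compounds, compound 3 also reaches only a limit, so no step between compound 3 and compound 4 can be read. The compounds shown therefore leave open at what concentration any of them would become cytotoxic, and whether any of the changes among them alters this: the limit of > 24000 nM in this assay, at which 4 of the 4 values shown sit.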